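The source may hold more compounds than are shown below. What is called first, only, known or untested is meant among the compounds shown, and "the series" means these compounds.

The series rests on one shared core, first seen in compound 1 `COc1cc(-c2nnc3n2NC(c2ccco2)C(C(=O)c2ccc(C)cc2)S3)cc(OC)c1OC`, which was tested in a functional assay on MCF7 cells (Homo sapiens) for cytotoxicity, read by MTT assay, with a stated time of 48 h; a lower number here means a stronger inhibitor, a higher number a weaker inhibitor. In that assay compound 1 gives > 100000 nM, a limit of the assay rather than a number. Compound 2 `COc1cc(-c2nnc3n2NC(c2ccco2)C(C(=O)c2cccs2)S3)cc(OC)c1OC` carries thiophen-2-yl in place of 4-methylphenyl on a carbonyl carbon; in this assay compound 2 gives > 100000 nM, again only a limit. Compound 3 `COc1cc(-c2nnc3n2NC(c2ccco2)C(C(=O)c2ccc(-c4ccccc4)cc2)S3)cc(OC)c1OC` carries phenyl in place of methyl on an aromatic carbon; in this assay compound 3 gives > 100000 nM, once more a limit. Compound 3 thus stands nowhere apart from its neighbours: all three values sit at the same limit (the limit of > 100000 nM in this assay, at which 3 of the 3 values shown sit), so a step that the two limits leave unreadable from compound 1 to compound 2, a step that the two limits leave unreadable from compound 1 to compound 3 and a step that the two limits leave unreadable from compound 2 to compound 3 are all unreadable.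

Compound 4 `COc1cc(-c2nnc3n2NC(c2ccco2)C(C(=O)c2ccc(Br)cc2)S3)cc(OC)c1OC` differs from compound 3 by bromo in place of phenyl on an aromatic carbon. For the measured compounds named here, the steps that bear on this change are a step that the two limits leave unreadable from compound 1 to compound 3 and a step that the two limits leave unreadable from compound 2 to compound 3, and neither gives any size, since no value left the limit. Compound 4 is therefore expected to remain at or near that limit, with an estimated step that the limit leaves unreadable from compound 3 to compound 4. The estimate for compound 4 in this assay is 150000 nM, expected to fall between 50000 nM and 500000 nM.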

Compound 4, half-maximal inhibitory concentration: > 100000 nM
Compound 4: only a limit was reported; the forecaster's own chance of this, stated with the estimate: 85%; the middle value lies beyond the limit too.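

In this assay compound 4 gives > 100000 nM, again a limit and not a number. Its steps from compound 1, compound 2 and compound 3 cannot be read, so no new step emerges: the limit of > 100000 nM in this assay, at which 4 of the 4 values shown sit.

The compounds shown leave open whether any group on the carbonyl carbon would bring a value off this limit.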